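N-Methylation of a Hydroxymethyl Thiophene Amine: Expected Binding

The source may report more compounds than this note shows. Statements on the series, on what has been measured and on what is new or still open speak of the compounds shown alone.

Measured so far in an assay on membranes from liver for displacement of a labelled ligand from Sigma intracellular receptor 2 (Rattus norvegicus), read by scintillation counting, with a stated time of 120 min, in the presence of a further agent that is not named here; a higher number here means a weaker inhibitor, a lower number a stronger inhibitor:
compound 1 `CN(CCCc1ccccc1)C1CCc2ccsc2CC1`, 13 nM
compound 2 `OCc1cc2c(s1)CCC(NCCCc1ccccc1)CC2`, 30 nM
compound 3 `OCc1cc2c(s1)CCC(NCCCCc1ccccc1)CC2`, 73 nM

Compound 2 stands second of the three numbers in this assay: compound 1 gives a lower number and compound 3 a higher one, and both gaps are beyond the scatter. Going by the values given here, the only step between compounds that differ in one place is a 2.4-fold higher number from compound 2 to compound 3 (0.39 log units; beyond the scatter), which concerns the chain and not the nitrogen.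

Compound 4 `CN(CCCc1ccccc1)C1CCc2cc(CO)sc2CC1` differs from compound 2 by methyl in place of hydrogen on an amine nitrogen. Among the compounds with values here, no measured pair isolates this change. Compound 1 carries the same methyl on the nitrogen and gives 13 nM, but it also lacks the hydroxymethyl group of compound 2, so its value speaks only indirectly. On that basis a small step in this assay is expected, towards a lower number, as in a 2.0-fold lower number from compound 2 to compound 4 (0.30 log units; within the scatter). Compound 4 is therefore estimated at 15 nM, with a range from 5 nM to 45 nM.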

Compound 4, inhibition constant: 21 nM
Compound 4: middle estimate off by 1.4-fold (0.15 log units), on the low side; measured number inside the range.
By their numbers in this assay, from the lowest: compounds 1, 4 and 2 (each within the scatter of the next, the first and the last beyond it); then compound 3.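

In this assay the amine nitrogen now has a direct reading: methyl in place of hydrogen there leaves the number within the scatter (a 1.4-fold lower number from compound 2 to compound 4 (0.15 log units; within the scatter)). Going by these compounds alone, compound 4 also gives the first direct reading of hydroxymethyl in place of hydrogen on an aromatic carbon with the methyl already on the nitrogen, and this step too stays within the scatter (a 1.6-fold higher number from compound 1 to compound 4 (0.21 log units; within the scatter)). Nothing available explains either result.

Going by these compounds, it remains open whether an ethyl or a benzyl group on the same nitrogen would also stay within the scatter, and whether the methyl would behave the same way on the longer chain of compound 3. On these data alone, it is equally open how a carboxylic acid or an aminomethyl group would read in place of the hydroxymethyl.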